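This account rests on a few compounds, and the source may have more. Where it says the series, first, only, none or still open, it means among the compounds named here.

Measured in a functional assay on HCT-116 cells (Homo sapiens) for inhibition, read by CCK-8 assay, with a stated time of 48 h; on this read-out lower numbers stand for stronger inhibition and higher numbers for weaker inhibition:
Compound 1 `COc1cc(-c2ccnc3cc(-c4ccc(C(F)(F)F)cc4)nn23)cc(OC)c1OC`: 1860 nM
Compound 2 `COc1cc(-c2ccnc3cc(-c4ccc(C(C)=O)cc4)nn23)cc(OC)c1OC`: 4390 nM

Going by the values given here, of these two numbers, the one for compound 2, 4390 nM, is the higher. Compound 3 `COc1cc(-c2ccnc3cc(-c4ccc5ccn(C)c5c4)nn23)cc(OC)c1OC` keeps the shared core but carries 1-methyl-1H-indol-6-yl in place of 4-acetylphenyl on an aromatic carbon. Among the compounds with values here, only one measured step bears on this change, and only loosely: a 2.4-fold higher number from compound 1 to compound 2 (0.37 log units; beyond the scatter), a modest shift that came from acetyl in place of trifluoromethyl. That exchange left the six-membered ring in place, whereas here the whole group is replaced, so a larger step is expected. Within the data shown here, with compound 2 at the high end of the numbers at 4390 nM, and no measured compound carrying this group, the direction is a tentative expectation towards a lower number. The expected change is an 8.8-fold lower number from compound 2 to compound 3 (0.94 log units; beyond the scatter). In this assay, compound 3 is estimated at 500 nM, with an expected range of 50 nM to 3000 nM.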

Compound 3, half-maximal inhibitory concentration: 1040 nM
For compound 3 the middle estimate is 2.1-fold (0.32 log units) below the measured one; the range from low to high includes it.
By their numbers in this assay, from the lowest: compounds 3 and 1 (each within the scatter of the next); then compound 2.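

In this assay, a two-ring 1-methyl-1H-indol-6-yl group in place of the single-ring 4-acetylphenyl gives a 4.2-fold lower number from compound 2 to compound 3 (0.63 log units; beyond the scatter), so this aromatic carbon of the five-membered ring with 2 nitrogen accepts a group that is not a substituted phenyl. Set against 4-(trifluoromethyl)phenyl, the same group gives a 1.8-fold lower number from compound 1 to compound 3 (0.25 log units; within the scatter), so these two groups cannot be told apart here, and only compound 2 stands off from both of the others. Nothing given here explains why the indole and trifluoromethyl compounds sit together or why compound 2 differs.

The compounds shown leave open whether the methyl group on the indole matters, as a plain 1H-indol-6-yl group would show. They also leave open how this position would respond to a phenyl ring carrying an amine or a carboxylic acid.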